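Decyl Chain in Place of a Difluorophenyl Ring

This account rests on a few compounds, and the source may have more. Where it says the series, first, only, none or still open, it means among the compounds named here.

compound 1 `O=C1O[C@H]([C@@H](O)Cn2cc(-c3cc(F)cc(F)c3)nn2)C(OCc2ccccc2)=C1OCc1ccccc1`
compound 2 `CC(C)(C)OC(=O)N1CCN(C(=S)SCc2cn(C[C@H](O)[C@H]3OC(=O)C(OCc4ccccc4)=C3OCc3ccccc3)nn2)CC1`
compound 3 `COc1ccccc1-c1cn(C/C=C2\OC(=O)C(OCc3ccccc3)=C2OCc2ccccc2)nn1`

In a functional assay on MCF7 cells (Homo sapiens) for antiproliferative activity, read by MTT assay, with a stated time of 72 h (a lower number here means a stronger inhibitor, a higher number a weaker inhibitor), compound 1 gives 27700 nM. Compound 2 reaches only the limit of the assay, > 100000 nM. Compound 3 likewise stops at the limit, > 100000 nM. Going by the values given here, compound 1 thus holds the only measured number among the three; the other two values are limits, and (the limit of > 100000 nM in this assay, at which 2 of the 3 values shown sit). Among the compounds with values here, no step between two measured compounds is available here, so the size of any change must be judged without a precedent.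

Compound 4 `CCCCCCCCCCc1cn(C[C@H](O)[C@H]2OC(=O)C(OCc3ccccc3)=C2OCc2ccccc2)nn1` differs from compound 1 in one place: decyl in place of 3,5-difluorophenyl on an aromatic carbon. The step is expected to be a 1.6-fold higher number from compound 1 to compound 4 (0.21 log units; within the scatter), toward somewhat weaker inhibition and close to the edge of the usual scatter. Compound 4 is therefore estimated at 45000 nM, with a range from 12000 nM to 100000 nM.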

Compound 4, half-maximal inhibitory concentration: 80 nM
Beside the measured number, compound 4's estimate is 560-fold (2.75 log units) above it; measured number below the stated range.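

At this aromatic carbon of the five-membered aromatic ring with 3 nitrogen, the group decides the read-out: in this assay, decyl in place of 3,5-difluorophenyl gives a 350-fold lower number from compound 1 to compound 4 (2.54 log units; beyond the scatter) and so the first measured size of a change here. The earlier compounds shown here offered no such step, and this one shows that a chain with no ring is accepted at this carbon in place of the aromatic ring. The other compounds add no number to compare: the limit of > 100000 nM in this assay, at which 2 of the 4 values shown sit.

Going by these compounds, whether the gain follows from the decyl chain's length or from the loss of the ring stays open. An octyl or dodecyl chain, or an unsubstituted phenyl ring, at this carbon would separate the two.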